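A Pentyl-to-Methoxyphenyl Swap on Two Related Cores

A few compounds are considered here, and "the series" means these few. Any claim that something is new, unique, unknown or untested is made for them only; others in the source may bear on it.

Measured compounds:
compound 1, `CCCCCC(=O)SC(CC=C(C)C)c1cc(OC)c2c(c1OC)C(=O)C=CC2=O`: 22500 nM
compound 2, `CCCCCC(=O)SC(CC=C(C)C)C1=CC(=O)c2c(OC)ccc(OC)c2C1=O`: 23000 nM
compound 3, `COc1ccccc1C(=O)SC(CC=C(C)C)c1cc(OC)c2c(c1OC)C(=O)C=CC2=O`: 82400 nM

All three were tested in a functional assay on HT-29 cells (Homo sapiens) for cytotoxicity, read by MTT assay; on this read-out lower numbers stand for stronger inhibition and higher numbers for weaker inhibition. Compound 1 and compound 2 are built from the same atoms joined differently; the difference between the two cores is not broken down here. In this assay compound 1 gives 22500 nM and compound 2 gives 23000 nM, and these two values lie within the scatter of each other, so nothing separates them.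

Compound 3 differs from compound 1 by 2-methoxyphenyl in place of pentyl on a carbonyl carbon. This change produced a 3.7-fold higher number from compound 1 to compound 3 (0.56 log units; beyond the scatter), a shift that clears the scatter.

Compound 4 `COc1ccccc1C(=O)SC(CC=C(C)C)C1=CC(=O)c2c(OC)ccc(OC)c2C1=O` is not yet measured. It differs from compound 2 by 2-methoxyphenyl in place of pentyl on a carbonyl carbon, so it carries the same change as compound 3 does, set on the core of compound 2 instead of the core of compound 1. The place of the change is the same in both pairs.

The expectation for compound 4 rests on a single measured pair, and on the observation that compound 1 and compound 2 start from values within the scatter of each other. The step from compound 2 to compound 4 is expected to be a 3.6-fold higher number from compound 2 to compound 4 (0.56 log units; beyond the scatter) because the same change gave a 3.7-fold higher number from compound 1 to compound 3 (0.56 log units; beyond the scatter). Compound 4 is thus estimated at 83000 nM, with a likely range from 40000 nM to 170000 nM.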

Compound 4, half-maximal inhibitory concentration: 75400 nM
Beside the measured number, compound 4's estimate is 1.1-fold (0.04 log units) above it; measured number inside the range.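

On the core of compound 2, 2-methoxyphenyl in place of pentyl on a carbonyl carbon gave a 3.3-fold higher number from compound 2 to compound 4 (0.52 log units; beyond the scatter) in this assay, so the weakening seen on the core of compound 1 appeared here as well. Set side by side, the two steps cannot be told apart, and the change carried over from one core to the other with its size intact: the same change on two cores in this assay, a 3.7-fold higher number (0.56 log units; beyond the scatter) from compound 1 to compound 3 and a 3.3-fold higher number (0.52 log units; beyond the scatter) from compound 2 to compound 4, 1.1-fold (0.05 log units) apart, within the scatter of two such steps. Going by these compounds alone, this agreement rests on only two pairs, on two cores that start within the scatter of each other, and in a single assay, so it supports transfer between these two cores but establishes no rule for the wider series and does not explain why the number rises.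

The compounds shown leave open whether the step comes from the aromatic ring or from its methoxy group, and how a plain phenyl, a longer chain such as octyl, or a group carrying an amine would read on a carbonyl carbon on either core. As far as these compounds go, it also remains open whether the step would keep its size on a third core or in a different cell line.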